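The compounds below may be only part of what the source reports. "The series", "measured", "known", "first", "only" and "open" are said of these compounds alone.

Compound 1 `CCOc1ccc2c(=O)c(-c3ccc(O)cc3)coc2c1`: 300 nM in an assay on isolated protein (Cricetulus griseus) for inhibition of Monoamine oxidase (Homo sapiens); on this read-out higher numbers stand for weaker inhibition and lower numbers for stronger inhibition
Compound 2 `O=c1c(-c2ccc(O)cc2)coc2cc(OCCCCCCBr)ccc12`: 2000 nM
Compound 3 `O=c1c(-c2ccc(O)cc2)coc2cc(OCCCCBr)ccc12`: 4000 nM

Compound 3 stands at the highest number of the three, with compound 2 nearest to it and compound 1 furthest away. Compound 4 `O=c1c(-c2ccc(O)cc2)coc2cc(OCCC3OCCCO3)ccc12` differs from compound 3 by a group of 6 heavy atoms (4 carbon, 2 oxygen; one six-membered non-aromatic ring with 2 hetero atoms) in place of a group of 3 heavy atoms (2 carbon, 1 bromine; no ring), on a saturated chain carbon, two bonds along the chain from an oxygen on an aromatic ring. Among the measured compounds shown here, the steps that bear on this are a 6.7-fold higher number from compound 1 to compound 2 (0.82 log units; beyond the scatter) and a 13-fold higher number from compound 1 to compound 3 (1.12 log units; beyond the scatter), both of which follow an extension of the chain on this carbon, while a 2.0-fold higher number from compound 2 to compound 3 (0.30 log units; within the scatter). The change to compound 4 again lengthens the chain on the same carbon, so a small further step upward, or none beyond the scatter, is expected for compound 4. Compound 4 is therefore estimated at 5000 nM, within 1500 nM to 16000 nM, which means an expected 1.3-fold higher number from compound 3 to compound 4 (0.10 log units; within the scatter).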

Compound 4, half-maximal inhibitory concentration: 7000 nM
Compound 4: the middle estimate sits 1.4-fold (0.15 log units) below what was measured, within the range that was stated.
By their numbers in this assay, from the lowest: compound 1; then compounds 2, 3 and 4 (each within the scatter of the next, the first and the last beyond it).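

In this assay, putting a six-membered non-aromatic ring with 2 hetero atoms in place of 2-bromoethyl gives a 1.8-fold higher number from compound 3 to compound 4 (0.24 log units; within the scatter), so at this carbon a group without bromine and with 2 hydrogen-bond acceptors reads the same as the bromo chain. The same ring also gives a 3.5-fold higher number from compound 2 to compound 4 (0.54 log units; beyond the scatter) and a 23-fold higher number from compound 1 to compound 4 (1.37 log units; beyond the scatter), which leaves all three larger groups on this carbon above compound 1 at 300 nM. No evidence here accounts for these steps. Going by these compounds, whether an amine or a carboxylic acid on this saturated chain carbon would bring the number back towards that of compound 1 remains open.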